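A Cyclohexyl Swap on the Ring Nitrogen

The source may report more compounds than this note shows. Statements on the series, on what has been measured and on what is new or still open speak of the compounds shown alone.

In a functional assay on HeLa cells (Homo sapiens) for antiproliferative activity, read by MTT assay, with a stated time of 72 h (on this read-out lower numbers stand for stronger inhibition and higher numbers for weaker inhibition), compound 3 `COc1cccc(N2C(=O)COc3ccc(-c4cnc5ccccc5c4)cc32)c1` gives 11400 nM. This lies within the scatter of compound 2 `COc1ncc(-c2ccc3c(c2)NC(=O)CO3)cc1NS(=O)(=O)c1ccc(F)cc1` at 7110 nM, and it is a higher number, beyond the scatter, than compound 1 `COc1ncc(-c2ccc3c(c2)N(c2ccc(C)cc2)C(=O)CO3)cc1NS(=O)(=O)c1ccc(F)cc1` at 4650 nM. Compound 4 `O=C1COc2ccc(-c3cnc4ccccc4c3)cc2N1C1CCCCC1` differs from compound 3 as follows: cyclohexyl in place of 3-methoxyphenyl on an amide-type nitrogen in a ring. Among the compounds with values here, the one measured step on this nitrogen, a 1.5-fold higher number from compound 1 to compound 2 (0.18 log units; within the scatter), exchanged 4-methylphenyl for hydrogen, and the rest of that molecule differs from compound 3. Within the data shown here, with only this step as a guide, no change beyond the scatter is expected. The estimated step is a 1.0-fold lower number from compound 3 to compound 4 (0.02 log units; within the scatter). For compound 4 the expected value is 11000 nM, with an estimated range of 4500 nM to 28000 nM.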

Compound 4, half-maximal inhibitory concentration: 19700 nM
Estimate against measurement, compound 4: 1.8-fold (0.25 log units) below, and the stated range covers the measured number.
By their numbers in this assay, from the lowest: compounds 1, 2, 3 and 4 (each within the scatter of the next, the first and the last beyond it).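

Exchanging 3-methoxyphenyl for cyclohexyl on the amide-type nitrogen in a ring gives a 1.7-fold higher number from compound 3 to compound 4 (0.24 log units; within the scatter). The earlier compounds had shown only 4-methylphenyl and hydrogen on this nitrogen, whereas this step shows that a non-aromatic carbon ring, without the oxygen of the methoxy group, leaves the number within the scatter of the aromatic group it replaces. Nothing available here speaks to why this exchange has so small an effect.

From the compounds shown here alone, what remains open is how an amine or a carboxylic acid on this nitrogen would read, and whether hydrogen there would also stay within the scatter on the core of compound 3.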